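Aryl urea variation on the shared core

The source may hold more compounds than are shown below. What is called first, only, known or untested is meant among the compounds shown, and "the series" means these compounds.

Measured in a functional assay on SF-295 cells (Homo sapiens) for inhibition, read by sulforhodamine B assay, with a stated time of 48 h; on this read-out lower numbers stand for stronger inhibition and higher numbers for weaker inhibition:
compound 1 `COc1cc(-c2nn(-c3cccc(NC(=O)Nc4cc(C(F)(F)F)cc(C(F)(F)F)c4)c3)cc2-c2ccncc2)ccc1Cl` — 400 nM
compound 2 `COc1cc(-c2nn(-c3cccc(NC(=O)c4cccc(C(F)(F)F)c4)c3)cc2-c2ccncc2)ccc1Cl` — 1020 nM
compound 3 `COc1cc(-c2nn(-c3cccc(NC(=O)Nc4ccc(Cl)c(Cl)c4)c3)cc2-c2ccncc2)ccc1Cl` — 690 nM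

Compound 3 gives the second highest of the three numbers; compound 2 sits nearest, and compound 1 furthest, both within the scatter. Compound 4 `COc1cc(-c2nn(-c3cccc(NC(=O)Nc4cccc(C(F)(F)F)c4)c3)cc2-c2ccncc2)ccc1Cl` differs from compound 3 by 3-(trifluoromethyl)phenyl in place of 3,4-dichlorophenyl on an amide-type nitrogen. For the measured compounds named here, no measured step swaps one aryl group for another on this nitrogen. Going by the values given here, the only step, a 1.5-fold lower number from compound 2 to compound 3 (0.17 log units; within the scatter), exchanges an amide for a urea and stays within the scatter; compound 1 and compound 3, both ureas with different aryl substitution, also lie within the scatter of each other. The step to compound 4 is therefore expected to stay within the scatter, a 1.3-fold lower number from compound 3 to compound 4 (0.10 log units; within the scatter). Compound 4 is estimated at 550 nM, between 250 nM and 1200 nM.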

Compound 4, half-maximal inhibitory concentration: 310 nM
Estimate against measurement, compound 4: 1.8-fold (0.25 log units) above, within the range that was stated.
By their numbers in this assay, from the lowest: compounds 4, 1, 3 and 2 (each within the scatter of the next, the first and the last beyond it).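

For the compounds shown here, on the amide-type nitrogen, 3-(trifluoromethyl)phenyl in place of 3,4-dichlorophenyl gives the first aryl swap that clears the scatter, if modestly (a 2.2-fold lower number from compound 3 to compound 4 (0.35 log units; beyond the scatter)). With 3-(trifluoromethyl)phenyl held constant, the exchange of amide for urea also lies beyond the scatter (a 3.3-fold lower number from compound 2 to compound 4 (0.52 log units; beyond the scatter)), unlike the step from compound 2 to compound 3. Hydrogen in place of trifluoromethyl on an aromatic carbon stays within the scatter (a 1.3-fold lower number from compound 1 to compound 4 (0.11 log units; within the scatter)). No measurement at hand accounts for these steps. Open, on these data alone, is how a nitrile or a methoxy on this aryl ring would read, and whether an amine there would hold the number.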